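Replacing 4-methoxyphenyl with 3,4-difluorophenyl on the carbonyl carbon

The source may report more compounds than this note shows. Statements on the series, on what has been measured and on what is new or still open speak of the compounds shown alone.

Of the compounds shown here, two with a shared core have been measured. Compound 1 `COc1ccc(C(=O)/C=C/c2cc(-c3cc(OC)c(OC)c(OC)c3)n[nH]2)cc1OC` carries a methoxy that compound 2 `COc1ccc(C(=O)/C=C/c2cc(-c3cc(OC)c(OC)c(OC)c3)n[nH]2)cc1` lacks. In a functional assay on UACC-257 cells (Homo sapiens) for cytotoxicity, read by sulforhodamine B assay, with a stated time of 48 h, tested at 0.1 uM (on this read-out higher numbers stand for a weaker effect at the one concentration tested and lower numbers for a stronger effect), compound 1 gives 89%, and compound 2 gives 97%. Going by the values given here, the only step known so far, a number 8 percentage points higher from compound 1 to compound 2 (within the scatter), is hydrogen in place of methoxy on an aromatic carbon. Compound 2 thus holds the highest of the two numbers, with compound 1 nearest and within the scatter of it.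

Compound 3 `COc1cc(-c2cc(/C=C/C(=O)c3ccc(F)c(F)c3)[nH]n2)cc(OC)c1OC` has not yet been measured. It differs from compound 2 in one place: 3,4-difluorophenyl in place of 4-methoxyphenyl on a carbonyl carbon. Among the compounds with values here, no measured step touches this part of the molecule; the single step available, a number 8 percentage points higher from compound 1 to compound 2 (within the scatter), concerns another group and stayed within the scatter. Nothing in the data points to a direction for the new change, so a step of a number 3 percentage points lower from compound 2 to compound 3 (within the scatter) is expected, none beyond the scatter. Compound 3 is therefore estimated at 94% in this assay, with a range from 80% to 106%.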

Compound 3, a percentage reported as activity, at one concentration (the size of the read-out at that concentration, not a potency): 92%
Compound 3: the middle estimate sits 2 percentage points above what was measured; low and high end bracket the measured number.
By their numbers in this assay, from the lowest: compounds 1, 3 and 2 (each within the scatter of the next).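

In this assay, going by these compounds alone, the group on the carbonyl carbon is varied for the first time, and exchanging 4-methoxyphenyl for 3,4-difluorophenyl comes with a number 5 percentage points lower from compound 2 to compound 3 (within the scatter). Set against the 3,4-dimethoxyphenyl group of compound 1, the same exchange comes with a number 3 percentage points higher from compound 1 to compound 3 (within the scatter), so the three groups on this carbonyl carbon cannot be told apart at the one concentration tested, whether the ring carries methoxy groups or fluorine atoms. Nothing available explains why the read-out does not separate these compounds.

From the compounds shown here alone, it remains open whether any group on this carbonyl carbon can move the read-out beyond the scatter, for example a phenyl ring bearing an amine, a hydroxyl group or a carboxylic acid in place of the methoxy groups or fluorine atoms. Going by these compounds, the chain carrying the carbonyl and the shared core are the same in all three compounds, so it is also open whether a longer chain or an amide in place of the carbonyl would give a different picture.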